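The source may report more compounds than this note shows. Statements on the series, on what has been measured and on what is new or still open speak of the compounds shown alone.

Three compounds have been measured in a functional assay on DU-145 cells (Homo sapiens) for inhibition, read by trypan blue exclusion, with a stated time of 96 h; on this read-out higher numbers stand for weaker inhibition of growth and lower numbers for stronger inhibition of growth:

compound 1 `CC(=O)c1ccc(/C=C(/Sc2ccc(C)cc2)C(=O)c2ccc(Br)cc2)cc1` gives 50000 nM
compound 2 `Cc1ccc(S/C(=C/c2ccc(F)cc2F)C(=O)c2ccc(Br)cc2)cc1` gives > 100000 nM, a limit of the assay rather than a number
compound 3 `Cc1ccc(S/C(=C/c2ccc(N(C)C)cc2)C(=O)c2ccc(Br)cc2)cc1` gives > 100000 nM, likewise a limit of the assay

Compound 3 therefore stands at the edge of what this assay can report, with no number of its own. Only compound 1 carries a measured value, and that value is itself weak. Compound 2 and compound 3 share the same limit, (the limit of > 100000 nM in this assay, at which 2 of the 3 values shown sit).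

Compound 4 `Cc1ccc(S/C(=C/c2ccc(C)s2)C(=O)c2ccc(Br)cc2)cc1` is the unmeasured member. Against compound 3 the change is 5-methylthiophen-2-yl in place of 4-(dimethylamino)phenyl on a double-bonded chain carbon bound to a double-bonded chain carbon. Going by the values given here, no measured step touches a thiophene, so the bearing of the known steps is indirect: an at least 2.0-fold higher number from compound 1 to compound 3 (0.30 log units; that floor lies within the scatter) and an at least 2.0-fold higher number from compound 1 to compound 2 (0.30 log units; that floor lies within the scatter) both run from the one number in the set up to the limit, and a step that the two limits leave unreadable from compound 2 to compound 3 cannot be read at all. Every aryl variant shown sits at or near the weak end of this assay, and nothing in the data marks the 5-methylthiophen-2-yl group as likely to break that pattern. The expectation for compound 4 is therefore a weak number close to the limit, an at least 1.2-fold lower number from compound 3 to compound 4 (0.09 log units; that floor lies within the scatter), with a fair chance that only a limit is returned. Compound 4 is estimated at 80000 nM, with a range from 20000 nM to 300000 nM.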

Compound 4, concentration for 50% growth inhibition: > 100000 nM
Compound 4 gave a limit, no number; the forecaster's own chance of this, stated with the estimate: 50%; middle value at least 1.2-fold (0.09 log units) away from the limit.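

Going by these compounds alone, with 5-methylthiophen-2-yl on a double-bonded chain carbon bound to a double-bonded chain carbon, a five-membered aromatic ring with a hetero atom now stands at this place, where the earlier compounds all carried a six-membered aromatic ring of carbon only, and this assay shows an at least 2.0-fold higher number from compound 1 to compound 4 (0.30 log units; that floor lies within the scatter). The steps to compound 4 from compound 2 and from compound 3 cannot be read, as both ends of each are limits. The change of ring type thus gives no measurable number, and only compound 1 stands apart from the limit shared by compound 2, compound 3 and compound 4: the limit of > 100000 nM in this assay, at which 3 of the 4 values shown sit.

Going by these compounds, how far compound 2, compound 3 and compound 4 differ from one another remains unknown. On these data alone, whether a pyridine ring or a phenyl ring bearing a carboxylic acid at this place would give a number rather than a limit also stays open.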